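The source may hold more compounds than are shown below. What is called first, only, known or untested is meant among the compounds shown, and "the series" means these compounds.

Within the data shown here, compound 3 `CN1CCN(CCCCn2c3c(c4ccccc42)C(=O)c2c[n+]([O-])c4ccccc4c2C3=O)CC1` carries a 3-(4-methylpiperazin-1-yl)propyl group on the shared core, and in a functional assay on SH-SY5Y cells (Homo sapiens) for cytotoxicity, read by MTT assay, with a stated time of 72 h (a lower number here means a stronger inhibitor, a higher number a weaker inhibitor), compound 3 gives 100 nM, the only true number among the values shown. Compound 1 `O=C1c2c[n+]([O-])c3ccccc3c2C(=O)c2c1c1ccccc1n2Cc1cn(C[C@H](O)CO)nn1` reaches only a limit of the assay, > 1000 nM. Compound 2 `O=C1c2c[n+]([O-])c3ccccc3c2C(=O)c2c1c1ccccc1n2Cc1cn(CC(O)CO)nn1` likewise stops at a limit, > 1000 nM. Both of these carry a 1-(2,3-dihydroxypropyl)-1H-1,2,3-triazol-4-yl group instead, and the measured steps are an at least 10-fold lower number from compound 1 to compound 3 (1.00 log units; beyond the scatter) and an at least 10-fold lower number from compound 2 to compound 3 (1.00 log units; beyond the scatter).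

Compound 4 `O=C1c2c[n+]([O-])c3ccccc3c2C(=O)c2c1c1ccccc1n2CCCCN1CCNCC1` departs from compound 3 in one place: hydrogen in place of methyl on an amine nitrogen in a ring. This is hydrogen in place of methyl on an amine nitrogen in a ring. The two measured steps bear on this only loosely, as each exchanges the whole group and neither isolates the methyl. The piperazine ring stays in compound 4, so in this assay it is expected to remain close to compound 3 at 100 nM, with no step beyond the scatter and no firm direction. The expected change is a 1.2-fold higher number from compound 3 to compound 4 (0.08 log units; within the scatter). For compound 4 the estimated value is 120 nM, with an expected range from 35 nM to 420 nM.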

Compound 4, half-maximal inhibitory concentration: 1240 nM
Compound 4: the middle estimate sits 10-fold (1.01 log units) below what was measured, outside the stated range (above it).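

In this assay, exchanging only the methyl on the amine nitrogen in the ring for hydrogen gives a 12-fold higher number from compound 3 to compound 4 (1.09 log units; beyond the scatter), so this one position matters on its own. The earlier steps shown here replaced the whole 1-(2,3-dihydroxypropyl)-1H-1,2,3-triazol-4-yl group with 3-(4-methylpiperazin-1-yl)propyl on the saturated chain carbon bound to an aromatic nitrogen, and so could not separate the methyl from the rest of that group; this step shows that keeping the piperazine ring does not by itself keep the number of compound 3. The steps from compound 1 and from compound 2 to compound 4 cannot be read, as both of those compounds stand at a limit of the assay.

Nothing measured among these compounds bears on why removing the methyl has this effect. As far as these compounds go, it remains open whether an ethyl, a longer alkyl chain or an acetyl on this ring nitrogen would stay with the methyl or with hydrogen, and whether the methyl counts for as much with a shorter or longer chain joining the piperazine ring to the shared core.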